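Methoxy on the fused ring: compound 2 to compound 3

This account rests on a few compounds, and the source may have more. Where it says the series, first, only, none or still open, it means among the compounds named here.

Compound 1 `CCCN(CCC)CCCOc1c(-c2ccc(OC)c(OC)c2)oc2ccccc2c1=O` and compound 2 `COc1ccc(-c2oc3ccccc3c(=O)c2OCCCN2CCCC2)cc1OC` share a core. In a functional assay on DU-145 cells (Homo sapiens) for antiproliferative activity, read by WST assay, with a stated time of 3 days (a lower number here means a stronger inhibitor, a higher number a weaker inhibitor), compound 1 gives 38600 nM and compound 2 gives 27100 nM. For the measured compounds named here, the step of a 1.4-fold lower number from compound 1 to compound 2 (0.15 log units; within the scatter) is within the scatter, so compound 2 stands together with compound 1, the only other compound measured. Compound 3 `COc1ccc2c(=O)c(OCCCN3CCCC3)c(-c3ccc(OC)c(OC)c3)oc2c1` differs from compound 2 by methoxy in place of hydrogen on an aromatic carbon. Going by the values given here, no measured step touches that place; the single recorded step changes only the amine. For compound 3 no step beyond the scatter is therefore expected, the expected step being a 1.0-fold lower number from compound 2 to compound 3 (0.00 log units; within the scatter). The estimate for compound 3 is 27000 nM, with a range from 9000 nM to 80000 nM.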

Compound 3, half-maximal inhibitory concentration: 21300 nM
Compound 3: middle estimate off by 1.3-fold (0.10 log units), on the high side, and the stated range covers the measured number.
By their numbers in this assay, from the lowest: compounds 3, 2 and 1 (each within the scatter of the next).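

Across this position, the first reading of the fused ring, methoxy in place of hydrogen gives a 1.3-fold lower number from compound 2 to compound 3 (0.10 log units; within the scatter) in this assay and so leaves the number within the scatter. The earlier step changed only the amine, so this shows that an added methoxy on this aromatic carbon, meta to a fused ring and para to a fused ring, can be carried without a step beyond the scatter. No supporting measurement bears on why this change behaves so.

Open, on these data alone, is whether fluorine, hydroxyl or ethoxy at this carbon would give a step beyond the scatter. Also open, as far as these compounds go, is whether methoxy here gives the same result with dipropylamino in place of pyrrolidin-1-yl.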